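Isoquinolin-5-yl in place of pyrimidin-5-yl: expectation for compound 4

This account rests on a few compounds, and the source may have more. Where it says the series, first, only, none or still open, it means among the compounds named here.

Measured so far in a functional assay on A-375 cells (Homo sapiens) for inhibition, read by sulforhodamine B assay, with a stated time of 6 days; on this read-out higher numbers stand for weaker inhibition and lower numbers for stronger inhibition
compound 1 `CNCCNCc1cccc(-c2nc(NC3CCOCC3)c(C)c(-c3ccnc4[nH]ccc34)n2)c1` gives 18200 nM
compound 2 `CNCCNCc1cccc(-c2nc(NC3CCOCC3)c(C)c(-c3cncnc3)n2)c1` gives > 50000 nM (a limit, not a number)
compound 3 `CNCCNCc1cccc(-c2nc(Nc3ccccc3)c(C)c(-c3cccnc3)n2)c1` gives 10900 nM

Compound 2 has only a limit and no number (the limit of > 50000 nM in this assay, at which 1 of the 3 values shown sits). Any step starting from compound 2 therefore has a known direction at best, not a known size.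

Compound 4 `CNCCNCc1cccc(-c2nc(NC3CCOCC3)c(C)c(-c3cccc4cnccc34)n2)c1` keeps the core of compound 2 and carries isoquinolin-5-yl in place of pyrimidin-5-yl on an aromatic carbon.

For the measured compounds named here, one measured step bears on this change, at the same place on the core and with the (oxan-4-yl)amino group kept: an at least 2.7-fold higher number from compound 1 to compound 2 (0.43 log units; beyond the scatter). There, a two-ring group left and pyrimidin-5-yl entered. The change to compound 4 runs the other way, with pyrimidin-5-yl leaving and a two-ring group entering. A step of at least comparable size towards a lower number is therefore expected in this assay, though the limit of compound 2 hides its true size. Compound 1 at 18200 nM is the nearest reference for this expectation, while compound 3 differs from compound 2 in more than one place.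

The estimate means an expected at least 3.3-fold lower number from compound 2 to compound 4 (0.52 log units; beyond the scatter). For compound 4 the estimated value is 15000 nM, with an expected range of 5000 nM to 40000 nM.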

Compound 4, half-maximal inhibitory concentration: 12700 nM
Beside the measured number, compound 4's estimate is 1.2-fold (0.07 log units) above it, within the range that was stated.
By their numbers in this assay, from the lowest: compounds 3, 4 and 1 (each within the scatter of the next). At a limit, above all of these: compound 2.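

In this assay, with the (oxan-4-yl)amino group kept, the change to isoquinolin-5-yl gives an at least 3.9-fold lower number from compound 2 to compound 4 (0.59 log units; beyond the scatter), so the difference seen on leaving pyrimidin-5-yl is no longer tied to a single two-ring group. The two two-ring groups are not told apart at this place, next to the ring nitrogen and ortho to the methyl group: the comparison gives a 1.4-fold lower number from compound 1 to compound 4 (0.16 log units; within the scatter), although a six-membered aromatic ring of carbon only stands in place of a five-membered aromatic ring with 1 hetero atom. Compound 2 stays a limit rather than a number, and the true size of its step cannot be read: the limit of > 50000 nM in this assay, at which 1 of the 4 values shown sits.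

The compounds shown do not separate the added ring from the loss of a ring nitrogen of pyrimidin-5-yl; a single-ring phenyl group at this place, with the (oxan-4-yl)amino group kept, would bear on that. On these data alone, compound 3 differs from compound 4 in more than one place, so the role of the group on the amine stays open, and a cyclohexylamino group alongside the isoquinolin-5-yl group would address it.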